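Swapping Benzyl for Neopentyl on an Inactive Chalcone

The source may report more compounds than this note shows. Statements on the series, on what has been measured and on what is new or still open speak of the compounds shown alone.

Compound 1 `O=C(/C=C/c1ccc(O)cc1)c1c(O)cccc1OCc1ccccc1` was tested in a functional assay on ACHN cells (Homo sapiens) for antiproliferative activity, read by sulforhodamine B assay; on this read-out higher numbers stand for weaker inhibition of growth and lower numbers for stronger inhibition of growth. In this assay compound 1 gives > 30000 nM, which is a limit of the assay rather than a number. Among the measured compounds shown here, compound 2 `CC(C)(C)CCOc1cccc(O)c1C(=O)CCc1ccc(O)cc1` is the only other compound measured here. In this assay compound 2 gives > 30000 nM, again a limit and not a number. For the measured compounds named here, both values shown thus sit at the limit of > 30000 nM in this assay, at which 2 of the 2 values shown sit, so compound 1 stands at the weak end of what this assay can report, with no stronger compound to compare it with. Compound 3 `CC(C)(C)CCOc1cccc(O)c1C(=O)/C=C/c1ccc(O)cc1` is the compound still to be measured. Its difference from compound 1 is neopentyl in place of phenyl on a saturated chain carbon bound to an oxygen on an aromatic ring. Going by the values given here, no measured pair traces this change, and with every value shown resting at the limit, the step in this assay is expected to be none beyond the usual scatter. Compound 3 is therefore expected to give about 30000 nM, with a range from 10000 nM to 100000 nM, and most likely to be reported only as a limit. The expected step is a number no higher from compound 1 to compound 3 (the limit leaves the size open).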

Compound 3, concentration for 50% growth inhibition: 3140 nM
For compound 3 the middle estimate is 9.6-fold (0.98 log units) above the measured one, outside the stated range (below it).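

In this assay, the group on this oxygen proves able to change the outcome: benzyl to 3,3-dimethylbutyl gives an at least 9.5-fold lower number from compound 1 to compound 3 (0.98 log units; beyond the scatter), bringing growth inhibition into the measurable range on the core of compound 1. Compound 2 also carries 3,3-dimethylbutyl, but with a saturated chain leading to the carbonyl, and its > 30000 nM is a limit. Among the compounds shown, the new group therefore does not give a measurable value on its own, and only compound 3 moves off the limit: the limit of > 30000 nM in this assay, at which 2 of the 3 values shown sit.

Going by these compounds, compound 1 has only a limit, so the full size of the step remains open. The compounds shown also cannot separate the loss of the aromatic ring from the shape of the new chain, and a straight hexyl chain or an amine at this place could help to test that.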